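The source may hold more compounds than are shown below. What is called first, only, known or untested is meant among the compounds shown, and "the series" means these compounds.

Working notes on the series in an ADME assay on LL24 cells (Homo sapiens) for inhibition, read by MTT assay, with a stated time of 24 h; on this read-out lower numbers stand for stronger inhibition and higher numbers for weaker inhibition. Compound 1 `CC(C)(C)c1ccc(C(=O)N/N=C/c2ccc([N+](=O)[O-])o2)cc1` carries a tert-butyl group on the shared core. In this assay compound 1 gives > 200000 nM, which is a limit of the assay and not a number. Compound 2 `Cc1cccc(C(=O)N/N=C/c2ccc([N+](=O)[O-])o2)c1` carries a methyl group on the same core. In this assay compound 2 gives > 200000 nM, again a limit of the assay rather than a number. Among the compounds with values here, compound 1 therefore stands at the limit of > 200000 nM in this assay, at which 2 of the 2 values shown sit; no numerical value is known for it, and no step between measured compounds can be drawn within this set. Compound 3 `CCCCOc1ccc(C(=O)N/N=C/c2ccc([N+](=O)[O-])o2)cc1` is the next member to be examined. How compound 3 differs from compound 1: butoxy in place of tert-butyl on an aromatic carbon. With both known values sitting at the same limit, no step beyond the scatter is expected in this assay on going to compound 3. The expected step is a number no higher from compound 1 to compound 3 (the limit leaves the size open), that is, none beyond the scatter. For compound 3 the estimate in this assay is 200000 nM, with a range from 60000 nM to 400000 nM, and the assay is expected most likely to report only a limit once more.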

Compound 3, half-maximal inhibitory concentration: > 200000 nM
Compound 3 gave a limit, no number; the forecaster's own chance of this, stated with the estimate: 75%; the middle value sits exactly at the limit.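

No step can be read from compound 1 to compound 3 in this assay, since both sit at a limit of the assay and neither has a number: the limit of > 200000 nM in this assay, at which 3 of the 3 values shown sit.

The compounds shown leave open how far each lies past that limit, and whether any group on the shared core would give a number in this assay.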